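Methyl Ester to Cyclopropyl Amide on the Shared Core

This account rests on a few compounds, and the source may have more. Where it says the series, first, only, none or still open, it means among the compounds named here.

Compound 1 `CNC(=O)CCc1ccncc1-c1ccc2ccccc2c1` gives > 10000 nM in a functional assay on KB cells (Homo sapiens) for inhibition, read by sulforhodamine B assay, with a stated time of 72 h (a higher number here means a weaker inhibitor of growth, a lower number a stronger inhibitor of growth), which is a limit of the assay rather than a number.
Compound 2 `COC(=O)/C=C/c1ccncc1-c1ccc2ccccc2c1` gives 6730 nM in this assay.

Compound 2 therefore holds the only number shown, as the other value is the limit of > 10000 nM in this assay, at which 1 of the 2 values shown sits. Compound 3 `O=C(/C=C/c1ccncc1-c1ccc2ccccc2c1)NC1CC1` differs from compound 2 by cyclopropylamino in place of methoxy on a carbonyl carbon. Going by the values given here, the one measured step, an at least 1.4-fold lower number from compound 1 to compound 2 (0.17 log units; that floor lies within the scatter), swapped an amide for an ester together with a chain change, and stayed near the scatter floor. Returning to an amide here is expected to change little, perhaps a 1.2-fold higher number from compound 2 to compound 3 (0.08 log units; within the scatter). Compound 3 is estimated at 8000 nM, between 3000 nM and 25000 nM.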

Compound 3, concentration for 50% growth inhibition: 6050 nM
Compound 3: the middle estimate sits 1.3-fold (0.12 log units) above what was measured, and the stated range covers the measured number.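

On this carbonyl carbon, cyclopropylamino in place of methoxy adds a ring and a hydrogen-bond donor, yet in this assay the result is a 1.1-fold lower number from compound 2 to compound 3 (0.05 log units; within the scatter), so these two compounds do not separate the ester from this amide. Set against the saturated methylamide, the result is an at least 1.6-fold lower number from compound 1 to compound 3 (0.21 log units; that floor lies within the scatter), and that comparison gives only a floor, since compound 1 carries a limit of the assay rather than a number: the limit of > 10000 nM in this assay, at which 1 of the 3 values shown sits.

From the compounds shown here alone, whether a carboxylic acid at this carbonyl carbon, or a longer chain on the amide nitrogen, would move the number beyond the scatter remains open. So does whether any group here brings growth inhibition far below the level of compound 2 and compound 3.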